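This account rests on a few compounds, and the source may have more. Where it says the series, first, only, none or still open, it means among the compounds named here.

Of the compounds shown here, two have numbers so far in a functional assay on HCT-116 cells (Homo sapiens) for inhibition, read by CCK-8 assay, with a stated time of 48 h; on this read-out lower numbers stand for stronger inhibition and higher numbers for weaker inhibition: compound 1 (`COc1ccc(CN(C(=O)CSC(=S)N2CCN(C)CC2)c2cc(OC)c(OC)c(OC)c2)cc1`) gives 2640 nM and compound 2 (`COc1ccc(CN(C(=O)CSC(=S)N2CCOCC2)c2cc(OC)c(OC)c(OC)c2)cc1`) gives 4130 nM, two values within the scatter of each other. The next change leads to compound 3 (`COc1ccc(CN(C(=O)CSC(=S)N2CCc3cc(Br)ccc32)c2cc(OC)c(OC)c(OC)c2)cc1`), with 5-bromo-2,3-dihydro-1H-indol-1-yl in place of morpholin-4-yl on a thiocarbonyl carbon. Among the measured compounds shown here, only one measured step bears on this change, a 1.6-fold higher number from compound 1 to compound 2 (0.19 log units; within the scatter), and it stays within the scatter. That step swaps one six-membered non-aromatic ring for another, whereas compound 3 brings in a six-membered aromatic ring of carbon only, so the step is a weak guide. No step beyond the scatter can be argued from it, and none is expected in this assay, though the uncertainty is wide. The estimated step is a 1.7-fold lower number from compound 2 to compound 3 (0.22 log units; within the scatter). For compound 3 the expected value is 2500 nM, with an estimated range of 400 nM to 12000 nM.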

Compound 3, half-maximal inhibitory concentration: 8060 nM
The estimate for compound 3 lay 3.2-fold (0.51 log units) below the measured number; low and high end bracket the measured number.
By their numbers in this assay, from the lowest: compounds 1, 2 and 3 (each within the scatter of the next, the first and the last beyond it).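

In this assay, the position on a thiocarbonyl carbon now gives its first step beyond the scatter: with 5-bromo-2,3-dihydro-1H-indol-1-yl in place of 4-methylpiperazin-1-yl, the result is a 3.1-fold higher number from compound 1 to compound 3 (0.48 log units; beyond the scatter), a modest change. With the same group in place of morpholin-4-yl, the result is a 2.0-fold higher number from compound 2 to compound 3 (0.29 log units; within the scatter), which stays within the scatter, so the position accepts a group with a six-membered aromatic ring of carbon only, and the change can be read only against compound 1. Nothing measured in the series gives a cause for this step.

The compounds shown do not separate the bromine from the ring system that carries it; the unsubstituted 2,3-dihydro-1H-indol-1-yl group would address that. Going by these compounds, an open-chain amine such as dimethylamino on the same carbon also remains open.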